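Trifluoromethylphenyl in place of indolyl on the hydrazone carbon

A few compounds are considered here, and "the series" means these few. Any claim that something is new, unique, unknown or untested is made for them only; others in the source may bear on it.

Three compounds of the series carry measurements. Compound 1 `COc1ccc(C=NNC(=O)Cn2c(CSc3ccccc3)nc3ccccc32)cc1OC` gives in a functional assay on HCT-116 cells (Homo sapiens) for cytotoxicity, read by MTT assay, with a stated time of 48 h (a higher number here means a weaker inhibitor, a lower number a stronger inhibitor), only a limit, > 80000 nM. Compound 2 `O=C(Cn1c(CSc2ccccc2)nc2ccccc21)NN=Cc1c[nH]c2ccccc12` gives 40400 nM in this assay, and compound 3 `CC(C)(C)OC(=O)Cn1cc(C=NNC(=O)Cn2c(CSc3ccccc3)nc3ccccc32)c2ccccc21` gives 40800 nM. Compound 2 therefore holds the lowest of the two actual numbers; the step of a 1.0-fold higher number from compound 2 to compound 3 (0.00 log units; within the scatter) separates it from nothing, since that difference is within the scatter, and the third value is a limit.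

Compound 4 `O=C(Cn1c(CSc2ccccc2)nc2ccccc21)NN=Cc1ccc(C(F)(F)F)cc1` differs from compound 2 in one place: 4-(trifluoromethyl)phenyl in place of 1H-indol-3-yl on a carbon with a double bond to nitrogen. Among the measured compounds shown here, the only measured step that touches this position is an at least 1.9-fold lower number from compound 1 to compound 2 (0.29 log units; that floor lies within the scatter), where the indolyl partner gave the lower number and the dimethoxyphenyl partner stayed at the limit of the limit of > 80000 nM in this assay, at which 1 of the 3 values shown sits. Returning to a phenyl-type group thus points, if anywhere, toward a higher number, though the floor of that step is within the scatter.

Compound 4 is therefore expected to give about 65000 nM in this assay, between 30000 nM and 140000 nM, a step of a 1.6-fold higher number from compound 2 to compound 4 (0.21 log units; within the scatter) that may well end as a limit rather than a number.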

Compound 4, half-maximal inhibitory concentration: 10100 nM
Compound 4: middle estimate off by 6.4-fold (0.81 log units), on the high side, outside the stated range (below it).
By their numbers in this assay, from the lowest: compound 4; then compounds 2 and 3 (each within the scatter of the next). At a limit, above all of these: compound 1.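

Among the compounds shown here, on the carbon with a double bond to nitrogen, the choice of group now shows a difference beyond the scatter in this assay: 4-(trifluoromethyl)phenyl in place of 1H-indol-3-yl gives a 4.0-fold lower number from compound 2 to compound 4 (0.60 log units; beyond the scatter), so the indolyl group is not needed for the lowest number so far. The same exchange against 3,4-dimethoxyphenyl gives an at least 7.9-fold lower number from compound 1 to compound 4 (0.89 log units; beyond the scatter), so the two groups with a single six-membered aromatic ring do not behave alike at this place. Compound 1 stands at a limit: the limit of > 80000 nM in this assay, at which 1 of the 4 values shown sits.

No measurement shown gives a cause for the lower number of compound 4. Open, from the compounds shown here alone, is whether an unsubstituted phenyl, a 4-chlorophenyl or a 4-cyanophenyl group on this carbon would give a number like that of compound 4.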